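The compounds below may be only part of what the source reports. "The series", "measured", "known", "first", "only" and "open" are said of these compounds alone.

Two compounds of the series have numbers in an ADME assay on HepG2 cells (Homo sapiens) for cytotoxicity, read by luminescence, CellTiter-Glo and ATP content, with a stated time of 72 h; a higher number here means that more compound is needed for the effect, a lower number that less compound is needed. Compound 1 `COc1ccc(Oc2ccc3c(NCCCNCc4cccc(OC)c4O)ccnc3c2)cc1` gives 5500 nM, and compound 2 `CCC(CC)c1ccc2c(NCCCNCc3cccc(OC)c3O)ccnc2c1` gives 410 nM, the lowest of the two numbers. Among the compounds with values here, the only measured step, a 13-fold lower number from compound 1 to compound 2 (1.13 log units; beyond the scatter), concerns the same place on the shared core. Compound 3 `COc1cccc(Oc2ccc3c(NCCCNCc4cccc(OC)c4O)ccnc3c2)c1` differs from compound 2 by 3-methoxyphenoxy in place of pentan-3-yl on an aromatic carbon. This change largely reverses that step, so a rise of comparable size in this assay is expected; whether 3-methoxyphenoxy behaves as 4-methoxyphenoxy did is not shown by the data. For compound 3 the expected value is 4000 nM (range 1500 nM to 12000 nM), an expected step of a 9.8-fold higher number from compound 2 to compound 3 (0.99 log units; beyond the scatter).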

Compound 3, half-maximal effective concentration: 5300 nM
Compound 3: middle estimate off by 1.3-fold (0.12 log units), on the low side; measured number inside the range.
By their numbers in this assay, from the lowest: compound 2; then compounds 3 and 1 (each within the scatter of the next).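

In this assay, 3-methoxyphenoxy in place of pentan-3-yl gives a 13-fold higher number from compound 2 to compound 3 (1.11 log units; beyond the scatter), so the large gap between pentan-3-yl and the aryl ether at this position holds for a second methoxyphenoxy group. With 3-methoxyphenyl in place of 4-methoxyphenyl on the oxygen, the result is a 1.0-fold lower number from compound 1 to compound 3 (0.02 log units; within the scatter), so the two methoxyphenoxy groups cannot be told apart here. No evidence is available to explain either step. From the compounds shown here alone, it remains open how a phenoxy group without methoxy, an amine or a carboxylic acid on this aromatic carbon would read in this assay.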